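This account rests on a few compounds, and the source may have more. Where it says the series, first, only, none or still open, it means among the compounds named here.

The study concerns four compounds tested in a functional assay on SK-MEL-28 cells (Homo sapiens) for inhibition, read by colorimetric assay and MTT assay, with a stated time of 72 h; on this read-out lower numbers stand for stronger inhibition and higher numbers for weaker inhibition. Compound 1 `COc1ccc(C(=O)NNC(=S)Nc2csc(-c3ccccc3)c2)cc1OC` gives 28000 nM in this assay. Compound 2 `COc1ccc(C(=O)NNC(=S)Nc2csc(-c3ccc(C)cc3)c2)cc1OC` carries a methyl in place of hydrogen on an aromatic carbon, the change described by methyl in place of hydrogen on an aromatic carbon, and in this assay compound 2 gives 19000 nM. The size of that step is a 1.5-fold lower number from compound 1 to compound 2 (0.17 log units; within the scatter), and it is the only measured instance of this change among the compounds shown.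

Compound 3 `Cc1ccc(-c2nnc(Nc3csc(-c4ccccc4)c3)s2)cc1` rests on a different core, and the difference between the two cores is not broken down here. In this assay compound 3 reaches only > 100000 nM, which is a limit of the assay and not a number. The line the limit of > 100000 nM in this assay, at which 1 of the 3 values shown sits, records where that limit sits. Compound 4 `Cc1ccc(-c2cc(Nc3nnc(-c4ccc(C)cc4)s3)cs2)cc1` has not yet been measured in this assay. It differs from compound 3 by the same change already seen between compound 1 and compound 2, namely (methyl in place of hydrogen on an aromatic carbon), at the same kind of place on the ring.

For compound 4 the expected step in this assay is a step that the limit leaves unreadable from compound 3 to compound 4, placed beside the measured 1.5-fold lower number from compound 1 to compound 2 (0.17 log units; within the scatter), and this expectation rests on the fact that the same change gave a step within the scatter because a 1.5-fold lower number from compound 1 to compound 2 (0.17 log units; within the scatter) was small. Compound 4 is therefore expected to give about 150000 nM in this assay. Its estimated range runs from 60000 nM to 400000 nM, and the assay is expected most likely to report again only a limit for compound 4.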

Compound 4, half-maximal inhibitory concentration: > 100000 nM
Compound 4: no number, only a limit; the forecaster's own chance of this, stated with the estimate: 75%; the middle value is on the limit's open side.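

In this assay compound 4 gives > 100000 nM as a limit of the assay and not a number. Among these compounds, compound 3 also stands at a limit, so no step from compound 3 to compound 4 can be read: the limit of > 100000 nM in this assay, at which 2 of the 4 values shown sit. The compounds shown leave open whether methyl in place of hydrogen on an aromatic carbon changes the value on the core of compound 3 at all.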